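The compounds below may be only part of what the source reports. "The series", "measured", "known", "first", "only" and "open" are said of these compounds alone.

Working notes on the series. In a functional assay on DU-145 cells (Homo sapiens) for cytotoxicity (a lower number here means a stronger inhibitor, a higher number a weaker inhibitor), compound 1 `COc1ccc(Cn2cc(/C=N\NC(=O)c3c[nH]c4ccccc34)c3cc(OC)ccc32)cc1` gives 19100 nM, and compound 2 `COc1ccc2c(c1)c(/C=N\NC(=O)c1cn(C)c3ccccc13)cn2Cc1ccc(Cl)cc1` gives 93000 nM; compound 2 stands with the highest of the two numbers, and the gap to compound 1 lies beyond the scatter. Compound 3 `COc1ccc2c(c1)c(/C=N\NC(=O)c1c[nH]c3ccccc13)cn2Cc1ccc(Cl)cc1` is not yet measured. It differs from compound 2 by hydrogen in place of methyl on an aromatic nitrogen. Among the measured compounds shown here, no measured pair shows this change directly; compound 1, which also carries the unsubstituted nitrogen, only hints at the direction. A modest move toward a lower number is expected, a 2.1-fold lower number from compound 2 to compound 3 (0.32 log units; beyond the scatter), within or near the scatter. Compound 3 is estimated at 45000 nM, between 15000 nM and 120000 nM.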

Compound 3, half-maximal inhibitory concentration: 50000 nM
Estimate against measurement, compound 3: 1.1-fold (0.05 log units) below; low and high end bracket the measured number.
By their numbers in this assay, from the lowest: compound 1; then compounds 3 and 2 (each within the scatter of the next).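

At the aromatic nitrogen, in this assay, hydrogen in place of methyl gives a 1.9-fold lower number from compound 2 to compound 3 (0.27 log units; within the scatter), so with the chloro group in place this change has no readable effect. Of the two single changes, only chloro in place of methoxy on an aromatic carbon separates a pair beyond the scatter, with a 2.6-fold higher number from compound 1 to compound 3 (0.42 log units; beyond the scatter) as its step. No evidence bears on the cause of either step. Open, on these data alone, is whether a longer chain or a chain ending in an amine on the aromatic nitrogen would shift the number, and whether the methyl step keeps its size with methoxy in place of chloro.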